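The source may hold more compounds than are shown below. What is called first, only, known or untested is meant among the compounds shown, and "the series" means these compounds.

Measured so far:
compound 1 `CCn1c(-c2ccccc2)nc2c(NC3CCCCC3)ncnc21` — 9020 nM
compound 2 `Cn1c(-c2ccccc2)nc2c(NC3CCCCC3)ncnc21` — > 30000 nM

Going by the values given here, compound 1 is one of two compounds tested in a functional assay on CHO cells for antagonist activity at adenosine receptor A2b (Homo sapiens), read by 33P incorporation, with a stated time of 20 min (on this read-out higher numbers stand for weaker inhibition and lower numbers for stronger inhibition), and in this assay compound 1 gives 9020 nM, the only actual number in the set. Compound 2 in this assay reaches only > 30000 nM, which is a limit of the assay rather than a number (the limit of > 30000 nM in this assay, at which 1 of the 2 values shown sits). Among the compounds with values here, the one measured step, an at least 3.3-fold higher number from compound 1 to compound 2 (0.52 log units; beyond the scatter), concerns the chain on the aromatic nitrogen of the shared core, not the ring on the amine nitrogen.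

Compound 3 `CCn1c(-c2ccccc2)nc2c(NC3CCC3)ncnc21` differs from compound 1 by cyclobutyl in place of cyclohexyl on a nitrogen on an aromatic ring. Within the data shown here, no measured step touches this ring, so nothing in the set bears directly on the change; the expectation rests on the value of compound 1 alone. The step from compound 1 to compound 3 is estimated as a 1.7-fold higher number from compound 1 to compound 3 (0.22 log units; within the scatter), a modest weakening. Compound 3 is therefore expected to give about 15000 nM, within a range from 5000 nM to 40000 nM.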

Compound 3, inhibition constant: 1440 nM
For compound 3 the middle estimate is 10-fold (1.02 log units) above the measured one; measured number below the stated range.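

Going by these compounds alone, the ring on the amine nitrogen, which no earlier pair of compounds had touched, turns out to matter in this assay: cyclobutyl in place of cyclohexyl on a nitrogen on an aromatic ring gives a 6.3-fold lower number from compound 1 to compound 3 (0.80 log units; beyond the scatter). Until now the only measured change had moved the number upward, so this is the first change shown to strengthen inhibition, and it does so with the chain on the aromatic nitrogen of the shared core left as it is. Nothing shown here accounts for the difference between these two rings.

From the compounds shown here alone, two rings cannot establish a trend with ring size, so it remains open whether cyclopentyl would fall between them or whether cyclopropyl would lower the number further. Also open, going by these compounds, is whether a longer chain, such as propyl, on the aromatic nitrogen would add to the cyclobutyl change.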